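This account rests on a few compounds, and the source may have more. Where it says the series, first, only, none or still open, it means among the compounds named here.

Measured so far in a functional assay on HT-29 cells (Homo sapiens) for inhibition, read by CellTiter-Glo, with a stated time of 72 h; on this read-out higher numbers stand for lower toxicity in this test and lower numbers for higher toxicity in this test
- compound 1 `CC1=C(CC(=O)N(C)CCN(C)C)c2cc(F)ccc2/C1=C\c1nc2ccccc2s1` at 2020 nM
- compound 2 `CC1=C(CC(=O)NCCN(C)C)c2cc(F)ccc2/C1=C\c1ccc(S(C)(=O)=O)cc1` at 12700 nM
- compound 3 `CC1=C(CC(=O)N2CCN(CCCN(C)C)CC2)c2cc(F)ccc2/C1=C\c1ccc([S+](C)[O-])cc1` at 23800 nM

Compound 3 lies within the scatter of compound 2 and well above compound 1, which holds the lowest number of the three. Compound 4 `CC1=C(CC(=O)N2CCN(c3ccncc3)CC2)c2cc(F)ccc2/C1=C\c1ccc([S+](C)[O-])cc1` differs from compound 3 by pyridin-4-yl in place of 3-(dimethylamino)propyl on an amine nitrogen in a ring. Within the data shown here, no measured pair isolates this change, so only the spread of the three values gives a guide. In this assay a modest move to a lower number is expected, from the top of that spread toward its middle. The expected step, a 2.4-fold lower number from compound 3 to compound 4 (0.38 log units; beyond the scatter), is a loose estimate. Compound 4 is expected at 10000 nM, with an estimated range of 3000 nM to 30000 nM here.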

Compound 4, half-maximal cytotoxic concentration: 9200 nM
Compound 4: the middle estimate sits 1.1-fold (0.04 log units) above what was measured; low and high end bracket the measured number.
By their numbers in this assay, from the lowest: compound 1; then compounds 4, 2 and 3 (each within the scatter of the next, the first and the last beyond it).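

In this assay, among these compounds, pyridin-4-yl in place of 3-(dimethylamino)propyl on an amine nitrogen in a ring gives a 2.6-fold lower number from compound 3 to compound 4 (0.41 log units; beyond the scatter), the first step that changes one place only. The read-out at this position therefore responds to replacing an open chain with an aromatic ring of the same heavy-atom count, though the step is modest. Open, as far as these compounds go, is how phenyl or methyl on that nitrogen would compare, which would separate the aromatic ring from its ring nitrogen. No measurement at hand explains this step.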